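Indazolyl in place of hydroxyethylphenyl: solubility notes

The source may report more compounds than this note shows. Statements on the series, on what has been measured and on what is new or still open speak of the compounds shown alone.

Compound 3 `CNC(=O)c1cc(C(=O)NC2CC2)cn(Cc2cccc([C@@H](C)O)c2)c1=O` carries a 3-(1-hydroxyethyl)phenyl group on a saturated chain carbon bound to an aromatic nitrogen of the shared core. In a physicochemical assay for solubility (on this read-out higher numbers stand for higher solubility and lower numbers for lower solubility), compound 3 reaches only a limit of the assay, >= 131 ug/mL. Compound 1 `CNC(=O)c1cc(C(=O)NC2CC2)cn(CC2CCCOC2)c1=O` likewise stops at a limit, >= 131 ug/mL. Compound 2 `CNC(=O)c1cc(C(=O)NC2CC2)cn(CC2CCOCC2)c1=O` stops at a limit too, >= 165 ug/mL. The steps a step that the two limits leave unreadable from compound 1 to compound 3 and a step that the two limits leave unreadable from compound 2 to compound 3 therefore carry no readable size, and the limit of >= 131 ug/mL in this assay, at which 2 of the 3 values shown sit, together with the limit of >= 165 ug/mL in this assay, at which 1 of the 3 values shown sits, hold all three values. Compound 4 `CNC(=O)c1cc(C(=O)NC2CC2)cn(Cc2cccc3cn[nH]c23)c1=O` differs from compound 3 by 1H-indazol-7-yl in place of 3-(1-hydroxyethyl)phenyl on a saturated chain carbon bound to an aromatic nitrogen. Within the data shown here, no measured step covers this change, so no direction beyond the scatter can be set from the data. Compound 4 is expected to give 100 ug/mL, within 35 ug/mL to 200 ug/mL. The expected step is an at least 1.3-fold lower number from compound 3 to compound 4 (0.11 log units; that floor lies within the scatter).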

Compound 4, solubility: >= 181 ug/mL
Compound 4: no number, only a limit; the forecaster's own chance of this, stated with the estimate: 45%; at least 1.8-fold (0.25 log units) between middle value and limit.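

In this assay compound 4 stops at a limit, >= 181 ug/mL. Like compound 1, compound 2 and compound 3, it has no number, so none of its steps to those compounds can be read. The compounds shown leave open whether 1H-indazol-7-yl and 3-(1-hydroxyethyl)phenyl differ at all on this read-out.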